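Swapping chloro for amino on a dichlorinated purine-like core

The source may hold more compounds than are shown below. What is called first, only, known or untested is meant among the compounds shown, and "the series" means these compounds.

Measured compounds:
Compound 1 `ClCc1ccccc1Cn1cnc2c(Cl)nc(Cl)nc21` gives 3270 nM in a functional assay on NCI-H322M cells (Homo sapiens) for cytotoxicity, read by sulforhodamine B assay, with a stated time of 48 h; a lower number here means a stronger inhibitor of growth, a higher number a weaker inhibitor of growth.
Compound 2 `ClCc1ccc(Cn2cnc3nc(Cl)nc(Cl)c32)cc1` gives 1900 nM in this assay.
Compound 3 `ClCc1cccc(Cn2cnc3nc(Cl)nc(Cl)c32)c1` gives 26900 nM in this assay.

All three compounds share the same core and differ only in where the chloromethyl arm sits on the benzyl ring. Compound 1 has the second highest of the three numbers in this assay. Its nearest neighbour is compound 2, whose number is lower but still within the scatter of repeated measurements, so the two cannot be told apart. Compound 3 stands furthest away, with a number that is higher by a margin beyond the scatter, so compound 3 is the weaker inhibitor of growth of the pair.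

Compound 4 `Nc1nc(Cl)c2ncn(Cc3ccccc3CCl)c2n1` has not yet been measured. It differs from compound 1 in one way: amino in place of chloro on an aromatic carbon. Among the measured compounds shown here, no measured pair shows what this exchange does, so there is no directly comparable step to lean on.

The expectation for compound 4 is a modest step towards a higher number in this assay, of a size that may fall within the scatter, written as a 1.8-fold higher number from compound 1 to compound 4 (0.26 log units; within the scatter). The estimate for compound 4 is therefore 6000 nM, with a plausible range from 1500 nM to 25000 nM.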

Compound 4, concentration for total growth inhibition: 29500 nM
Beside the measured number, compound 4's estimate is 4.9-fold (0.69 log units) below it, outside the stated range (above it).
By their numbers in this assay, from the lowest: compounds 2 and 1 (each within the scatter of the next); then compounds 3 and 4 (each within the scatter of the next).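

Amino in place of chloro on the aromatic carbon between two ring nitrogen atoms gives a 9.0-fold higher number from compound 1 to compound 4 (0.96 log units; beyond the scatter) in this assay, a step beyond the scatter. Among the compounds shown here, this is the first step in the set that isolates a change on the shared core itself, since the earlier compounds varied only in where the chloromethyl arm sits on the benzyl ring; it shows that the number in this assay responds clearly to what occupies this carbon, and that keeping chloro here goes with the lower number in this single pair. Nothing measured here explains the size of this step, so it stands as an observed outcome only.

On these data alone, whether the exchange would have a similar effect with the chloromethyl arm placed as in compound 2 or compound 3 remains open, as does the effect of the same exchange at the carbon that still carries chloro. Also open, as far as these compounds go, is how other groups on this carbon, such as methylamino, dimethylamino, methoxy or plain hydrogen, would compare with chloro and amino.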